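The source may hold more compounds than are shown below. What is called first, only, known or untested is meant among the compounds shown, and "the series" means these compounds.

In an ADME assay on HepG2 2.2.15 cells (Homo sapiens) for cytotoxicity, read by MTT assay, with a stated time of 72 h (a lower number here means that less compound is tolerated, a higher number that more compound is tolerated), three compounds sharing one core have been measured. Compound 1 `O=C(O)c1ccccc1C(=O)OCc1cccc2c1CCOC2=O` gives a true number, 130000 nM. Compound 2 `O=C(OCc1cccc2c1CCOC2=O)c1ccco1` gives only a limit, > 2350000 nM. Compound 3 `O=C(O)c1cccc2c1CCOC2=O` also gives only a limit, > 4540000 nM, so its position on the scale is not pinned to a number.

The step of interest leads to compound 4 `O=C1OCCc2c1cccc2C1OCCO1`, which has 1,3-dioxolan-2-yl in place of carboxy on an aromatic carbon. Among the measured compounds shown here, no measured pair here differs in one place alone, so the size of this step can only be judged loosely. A modest move towards a lower number in this assay is expected, because compound 1 gives 130000 nM and shows that a measurable value is possible with this core. The estimated change is an at least 3.0-fold lower number from compound 3 to compound 4 (0.48 log units; beyond the scatter). For compound 4 the expected value is 1500000 nM, with an estimated range of 300000 nM to 5000000 nM. A report of only a limit would be no surprise.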

Compound 4, half-maximal cytotoxic concentration: > 2580000 nM
Compound 4 was reported as a limit (the forecaster's own chance of this, stated with the estimate: 60%); middle value at least 1.7-fold (0.23 log units) from the limit.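

Compound 3 and compound 4 are both reported only as limits in this assay, so the step between them cannot be read. The compounds shown leave open whether 1,3-dioxolan-2-yl in place of carboxy on an aromatic carbon changes the tolerated concentration at all, and in which direction.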